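The source may report more compounds than this note shows. Statements on the series, on what has been measured and on what is new or still open speak of the compounds shown alone.

Compound 3 `CCCCCCCCN(C)C(=O)Cn1cc(Cc2cnc(=O)n(CCO)c2)c(=O)nc1SCc1ccc(F)cc1` is one of three measured compounds that share a common core and differ only in the group on a saturated chain carbon bound to an aromatic carbon. In a functional assay on a cell-free system (plasma) for inhibition of platelet-activating factor acetylhydrolase (Homo sapiens), tested at 100 nM (on this read-out higher numbers stand for more inhibition at the one concentration tested (going by the name of the read-out) and lower numbers for less inhibition), compound 3 gives 59%. Compound 1 `CCCCCCCCN(C)C(=O)Cn1cc(Cc2cnc(O)nc2)c(=O)nc1SCc1ccc(F)cc1` gives 66%, and compound 2 `CCCCCCCCN(C)C(=O)Cn1cc(Cc2cnc(=O)n(CC(=O)O)c2)c(=O)nc1SCc1ccc(F)cc1` gives 56%. The number of compound 3 sits within the scatter of both, as shown by a number 7 percentage points lower from compound 1 to compound 3 (within the scatter) and by a number 3 percentage points higher from compound 2 to compound 3 (within the scatter), and the remaining pair also stays within the scatter: a number 10 percentage points lower from compound 1 to compound 2 (within the scatter).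

Compound 4 `CCCCCCCCN(C)C(=O)Cn1cc(Cc2cnc(=O)n(CC(=O)NC)c2)c(=O)nc1SCc1ccc(F)cc1` has not yet been measured. It differs from compound 3 in one place: methylcarbamoyl in place of hydroxymethyl on a saturated chain carbon bound to an aromatic nitrogen. The measured step that bears most directly on this change is the one at the same position, where carboxy gave way to hydroxymethyl: a number 3 percentage points higher from compound 2 to compound 3 (within the scatter). Going by the values given here, nothing among the measured compounds points to a larger move when methylcarbamoyl enters, so compound 4 is expected to show a number 1 percentage points lower from compound 3 to compound 4 (within the scatter) in this assay. The estimate for compound 4 is therefore 58%, with a range from 45% to 70%.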

Compound 4, a percentage reported as inhibition, at one concentration (the size of the read-out at that concentration, not a potency): 63%
For compound 4 the middle estimate is 5 percentage points below the measured one; the range from low to high includes it.
By their numbers in this assay, from the lowest: compounds 2, 3, 4 and 1 (each within the scatter of the next).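

At the saturated chain carbon bound to an aromatic nitrogen, methylcarbamoyl joins hydroxymethyl and carboxy as a third group that stays within the scatter in this assay, with a number 4 percentage points higher from compound 3 to compound 4 (within the scatter) and a number 7 percentage points higher from compound 2 to compound 4 (within the scatter). The amide of compound 4 therefore reads the same as the alcohol of compound 3 and the acid of compound 2, and the comparison with the group of compound 1 on the saturated chain carbon bound to an aromatic carbon gives the same picture, with a number 3 percentage points lower from compound 1 to compound 4 (within the scatter). No measurement is at hand that would account for these numbers.

With only one concentration and every step within the scatter, the compounds shown do not reveal whether any group at this position changes inhibition. Going by these compounds, it remains open whether an amine such as 2-aminoethyl, a dimethylcarbamoyl group or a longer alkyl chain would leave the scatter.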